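Chloro for fluoro: compound 3 to compound 4

The source may hold more compounds than are shown below. What is called first, only, known or untested is meant among the compounds shown, and "the series" means these compounds.

Measured in a physicochemical assay for solubility (on this read-out lower numbers stand for lower solubility and higher numbers for higher solubility), each entry a limit of the assay and not a number:
- compound 1 `O=C(O)c1ccc(C(=O)/C(=C\c2ccc(Cl)c([N+](=O)[O-])c2)SCc2ccc(Cl)cc2)cc1`: < 1000 ug/mL
- compound 2 `O=C(O)c1ccc(C(=O)/C(=C\c2ccc(Br)c([N+](=O)[O-])c2)SCc2ccc(Cl)cc2)cc1`: < 1000 ug/mL
- compound 3 `O=C(O)c1ccc(C(=O)/C(=C\c2ccc(F)c([N+](=O)[O-])c2)SCc2ccc(F)cc2)cc1`: < 1000 ug/mL

Compound 3 stands at < 1000 ug/mL, which is a limit only. Going by the values given here, the series so far shows (the limit of < 1000 ug/mL in this assay, at which 3 of the 3 values shown sit).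

The change to compound 4 `O=C(O)c1ccc(C(=O)/C(=C\c2ccc(F)c([N+](=O)[O-])c2)SCc2ccc(Cl)cc2)cc1` is chloro in place of fluoro on an aromatic carbon, in words chloro in place of fluoro on an aromatic carbon, para to a large group. Among the compounds with values here, the one measured step that bears on it is a step that the two limits leave unreadable from compound 1 to compound 2, with bromo in place of chloro on an aromatic carbon. It offers no size and no direction to carry over, so no particular shift is expected in this assay.

The expected step is a step that the limit leaves unreadable from compound 3 to compound 4.

Compound 4 is estimated at 400 ug/mL, with an expected range of 100 ug/mL to 1000 ug/mL.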

Compound 4, solubility: < 1000 ug/mL
Compound 4: no number, only a limit; the forecaster's own chance of this, stated with the estimate: 90%; the middle value does not contradict the limit.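

No new step to compound 4 from compound 1, compound 2 or compound 3 can be read in this assay, since all four sit at one limit: the limit of < 1000 ug/mL in this assay, at which 4 of the 4 values shown sit.

Where compound 3 and compound 4 actually stand, and whether chloro in place of fluoro moves the read-out at all, stays open.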